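Benzyloxy Replaced by Phenyl: An Expected Outcome

The source may report more compounds than this note shows. Statements on the series, on what has been measured and on what is new or still open speak of the compounds shown alone.

Compound 1, `C=C[C@@](C)(/C=C/c1ccc(OCc2ccccc2)cc1)CCC=C(C)C`: > 26000 nM
Compound 2, `C=C[C@@](C)(/C=C/c1ccc(O)c(/C=C/C=C/c2ccccc2)c1)CCC=C(C)C`: > 26000 nM

In a functional assay on Raji cells (Homo sapiens) for cytotoxicity, with a stated time of 72 h (a lower number here means that less compound is needed, a higher number that more compound is needed for the effect), compound 1 gives no number at all, only a limit of the assay, > 26000 nM. Compound 2 likewise reaches only a limit, > 26000 nM. So compound 1 stands exactly where everything measured so far stands: at the limit of > 26000 nM in this assay, at which 2 of the 2 values shown sit. For the measured compounds named here, nothing here separates the two compounds, and no step between measured compounds is available that would show how any single change in structure moves the read-out.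

Compound 3, `C=C[C@@](C)(/C=C/c1ccc(-c2ccccc2)cc1)CCC=C(C)C`, has not yet been measured. It differs from compound 1 in one place: phenyl in place of benzyloxy on an aromatic carbon. Going by the values given here, with no measured step to lean on, the expectation rests only on the fact that both measured compounds sit at the limit. The step from compound 1 to compound 3 is therefore expected to be no larger than the usual scatter, with no clear direction, a number no higher from compound 1 to compound 3 (the limit leaves the size open). For compound 3 the expected value in this assay is 26000 nM, with a likely range from 8000 nM to 80000 nM, and most probably another limit rather than a number.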

Compound 3, half-maximal effective concentration: > 26000 nM
Compound 3: only a limit was reported (the forecaster's own chance of this, stated with the estimate: 75%); the middle value sits exactly at the limit.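

In this assay compound 3 gives > 26000 nM, which is a limit of the assay and not a number. Compound 1 also gives only a limit, and the step between these two compounds, phenyl in place of benzyloxy, cannot be read. The compounds shown leave open whether this swap changes the read-out at all, and which change to the shared core would yield an actual number.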